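The source may hold more compounds than are shown below. What is called first, only, known or untested is meant among the compounds shown, and "the series" means these compounds.

Of the compounds shown here, three sharing one core have so far been tested in a functional assay on HTB-54 cells (Homo sapiens) for cytotoxicity, read by MTT assay, with a stated time of 72 h; on this read-out higher numbers stand for weaker inhibition of growth and lower numbers for stronger inhibition of growth. Compound 1 `CSc1ccc(CNc2nc(SC)nc3ncccc23)cc1` gives 14800 nM. Compound 3 `CSc1nc(NCc2ccccc2)c2ccccc2n1` gives 82300 nM. Compound 2 `COc1ccc(CNc2nc(SC)nc3ccccc23)cc1` reaches only a limit of the assay, reported as > 100000 nM, so no number stands for it. Within the data shown here, the one measured step among them, hydrogen in place of methoxy on an aromatic carbon, reads an at least 1.2-fold lower number from compound 2 to compound 3 (0.08 log units; that floor lies within the scatter) and rests on (the limit of > 100000 nM in this assay, at which 1 of the 3 values shown sits).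

Compound 4 `COc1ccc(CNc2nc(S)nc3ccccc23)cc1` differs from compound 2 by hydrogen in place of methyl on a sulfur. Among the measured compounds shown here, no measured step touches the sulfur, so nothing here bears directly on this change; the expected shift is a number no higher from compound 2 to compound 4 (the limit leaves the size open), with no move beyond the scatter foreseen. Compound 4 is therefore estimated at 100000 nM, within 30000 nM to 300000 nM.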

Compound 4, concentration for total growth inhibition: 45500 nM
Estimate against measurement, compound 4: 2.2-fold (0.34 log units) above; the measured number falls inside the stated range.
By their numbers in this assay, from the lowest: compound 1; then compounds 4 and 3 (each within the scatter of the next). At a limit, above all of these: compound 2.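

Among these compounds, no earlier step touched this sulfur, and in this assay the change now has a direction: hydrogen in place of methyl on it gives an at least 2.1-fold lower number from compound 2 to compound 4 (0.34 log units; beyond the scatter). So removing the methyl from the sulfur lowers the number rather than leaving it unchanged. Compound 2 stands only at a limit, > 100000 nM, so the size of the step remains open: the limit of > 100000 nM in this assay, at which 1 of the 4 values shown sits.

On these data alone, it remains open whether an amine or a longer chain on the sulfur would lower the number further. The same change on compound 3 also remains unread.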